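From 4-hydroxyphenyl to 2-nitrophenyl in a growth assay

This account rests on a few compounds, and the source may have more. Where it says the series, first, only, none or still open, it means among the compounds named here.

Among the measured compounds shown here, in a functional assay on UACC-62 cells (Homo sapiens) for cytotoxicity, read by sulforhodamine B assay (a higher number here means a weaker inhibitor of growth, a lower number a stronger inhibitor of growth), compound 1 `CC1=CC[C@@H]([C@@](C)(O)CCCC(C)(C)NC(=S)N/N=C\c2ccc(C)cc2)CC1` gives 39000 nM and compound 2 `CC1=CC[C@@H]([C@@](C)(O)CCCC(C)(C)NC(=S)N/N=C\c2ccc(O)cc2)CC1` gives 40100 nM, so compound 2 stands level with the only other measured compound. Compound 3 `CC1=CC[C@@H]([C@@](C)(O)CCCC(C)(C)NC(=S)N/N=C\c2ccccc2[N+](=O)[O-])CC1` differs from it as follows: 2-nitrophenyl in place of 4-hydroxyphenyl on a carbon with a double bond to nitrogen. This places 2-nitrophenyl in place of 4-hydroxyphenyl on a carbon with a double bond to nitrogen. For the measured compounds named here, the only measured step, a 1.0-fold higher number from compound 1 to compound 2 (0.01 log units; within the scatter), involved no 2-nitrophenyl. It nevertheless offers no sign of a large change, so no step beyond the scatter is expected in this assay. The expected step is a 1.1-fold lower number from compound 2 to compound 3 (0.06 log units; within the scatter). For compound 3 the estimate is 35000 nM, with an expected range of 15000 nM to 80000 nM.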

Compound 3, concentration for total growth inhibition: 16600 nM
Compound 3: the middle estimate sits 2.1-fold (0.32 log units) above what was measured, and the stated range covers the measured number.
By their numbers in this assay, from the lowest: compound 3; then compounds 1 and 2 (each within the scatter of the next).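

In this assay, the earlier pair showed no movement at the carbon with a double bond to nitrogen, but 2-nitrophenyl in place of 4-hydroxyphenyl gives a 2.4-fold lower number from compound 2 to compound 3 (0.38 log units; beyond the scatter) and in place of 4-methylphenyl gives a 2.3-fold lower number from compound 1 to compound 3 (0.37 log units; beyond the scatter). Both steps are modest, yet beyond the scatter, so the number at this place can respond to the choice of aromatic group. Nothing at hand accounts for these steps.

Going by these compounds, whether they belong to the nitro group itself or to where it sits on the ring stays open, and so does what an amine or a carboxylic acid in its stead would give.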